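The source may report more compounds than this note shows. Statements on the series, on what has been measured and on what is new or still open speak of the compounds shown alone.

Compound 1 `CCCCNC(=O)c1cc(OC)n(-c2ccccc2)n1` gives 20.6%. Compound 2 `COc1cc(C(=O)Nc2cccc(C(F)(F)F)c2)nn1-c1ccccc1` gives 20.9%. Compound 3 `CCCCOc1cc(C(=O)NCC)nn1-c1ccccc1` gives 0%.

These numbers come from a functional assay on the whole organism (strain Wistar) for inhibition, with Rattus norvegicus as the target, read by paw edema, with stated times of 30 min and 3 h, at a dose of 100 mg/kg by the oral route; a higher number here means more inhibition at the dose given (going by the name of the read-out), a lower number less inhibition. Compound 3 stands lowest of the three: compound 1 lies above it by a margin beyond the scatter, and compound 2 lies above it by a similar margin, also beyond the scatter. Compound 4 `CCCCOc1cc(C(=O)N(CC)CC)nn1-c1ccccc1` differs from compound 3 by ethyl in place of hydrogen on an amide-type nitrogen. No measured pair shows this same change, so its effect in this assay has no precedent among these compounds. The step expected here is a number 6 percentage points higher from compound 3 to compound 4 (within the scatter), a small rise that may not reach beyond the scatter, since compound 3 sits at the floor of the read-out. Compound 4 is therefore estimated at 6%, with a range from 0% to 20%.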

Compound 4, a percentage reported as inhibition, in the whole organism at one dose (the size of the read-out at that dose, not a potency): 44.1%
Compound 4: the middle estimate sits 38.1 percentage points below what was measured; the measured number lies above the stated range.
By their numbers in this assay, from the lowest: compound 3; then compounds 1 and 2 (each within the scatter of the next); then compound 4.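

In this assay, ethyl in place of hydrogen on the amide-type nitrogen gives a number 44.1 percentage points higher from compound 3 to compound 4 (beyond the scatter) and leaves the rest of the structure unchanged. For the compounds shown here, this is the first comparison here between compounds that differ in one place, and it shows that this nitrogen is a position where a small change can carry the read-out clear of the scatter. The data offer no explanation for the size of this step.

As far as these compounds go, whether propyl groups or a ring amine such as piperidine at this nitrogen would hold the rise remains open. So does whether adding ethyl to the amide nitrogen of compound 1 would give a similar step.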